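The source may hold more compounds than are shown below. What is called first, only, known or untested is meant among the compounds shown, and "the series" means these compounds.

In a functional assay on the whole organism (blood, strain albino) with Mus musculus as the target, with stated times of 6 days and 3 h, at a dose of 1 mmol/kg by the oral route (on this read-out higher numbers stand for more inhibition at the one dose given (going by the name of the read-out) and lower numbers for less inhibition), compound 3 `CCN1C(=O)CCN(S(=O)(=O)c2ccc(-n3nc(C(=O)O)cc3C)cc2)C1=S` gives 1%, the lowest of the three numbers, though within the scatter of both compound 1 `CCN1C(=O)CCN(S(=O)(=O)c2ccc(-n3nc(C)cc3C)cc2)C1=S`, which gives 4%, and compound 2 `Cc1cc(C)n(-c2ccc(S(=O)(=O)N3CCC(=O)N(C4CCCCC4)C3=S)cc2)n1`, which gives 4%. Compound 4 `C=CCN1C(=O)CCN(S(=O)(=O)c2ccc(-n3nc(C(=O)O)cc3C)cc2)C1=S` differs from compound 3 by vinyl in place of methyl on a saturated chain carbon bound to an amide-type nitrogen in a ring. For the measured compounds named here, the measured step that bears on this place is no change at the digits printed from compound 1 to compound 2 (within the scatter), a far larger change on the same nitrogen than the one leading to compound 4; the other step, a number 3 percentage points lower from compound 1 to compound 3 (within the scatter), touches a different place. With all three readings standing near zero, no step beyond the scatter is expected in this assay, and compound 4 is expected to give 2%, between -6% and 12%, a step of a number 1 percentage points higher from compound 3 to compound 4 (within the scatter).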

Compound 4, a percentage reported as inhibition, in the whole organism at one dose (the size of the read-out at that dose, not a potency): 0%
Estimate against measurement, compound 4: 2 percentage points above, and the stated range covers the measured number.
By their numbers in this assay, from the lowest: compounds 4, 3, 1 and 2 (each within the scatter of the next).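

With the carboxy group in place, the change from ethyl to allyl on the amide-type nitrogen in a ring gives a number 1 percentage points lower from compound 3 to compound 4 (within the scatter) in this assay. The earlier step at this nitrogen came from compounds carrying methyl on the aromatic carbon, so the absence of a readable change now extends to a carboxy-bearing pair, and the added double bond brings no readable change either. Nothing at hand offers an explanation for this reading. On these data alone, whether a benzyl group or an amine-bearing chain on this nitrogen, or an ester in place of the carboxy group, would move the number beyond the scatter stays open.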